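The source may report more compounds than this note shows. Statements on the series, on what has been measured and on what is new or still open speak of the compounds shown alone.

Measured so far:
Compound 1, `CN(Cc1nnn(C)n1)[C@H](COCc1cc(C(F)(F)F)cc(C(F)(F)F)c1)c1ccccc1`, in an assay on CHO cells for displacement of a labelled ligand from Substance-P receptor (Homo sapiens) (on this read-out lower numbers stand for stronger inhibition and higher numbers for weaker inhibition), compound 1 gives 16 nM.
Compound 2, `CCN(Cc1n[nH]c(O)n1)[C@H](COCc1cc(C(F)(F)F)cc(C(F)(F)F)c1)c1ccccc1`, in this assay compound 2 gives 0.8 nM.

Compound 2 holds the lowest number of the two; the step of a 20-fold lower number from compound 1 to compound 2 (1.30 log units; beyond the scatter) separates it from compound 1. Compound 3, `CCCN(Cc1n[nH]c(O)n1)[C@H](COCc1cc(C(F)(F)F)cc(C(F)(F)F)c1)c1ccccc1`, differs from compound 2 by methyl in place of hydrogen on a saturated chain carbon, two bonds along the chain from an amine nitrogen, which read one bond further out is ethyl to propyl on the amine nitrogen. Among the compounds with values here, the single measured step, from compound 1 to compound 2, altered both the chain on the amine nitrogen and the ring it carries at once, so it does not isolate a chain lengthening; no measured step bears directly on the change to compound 3. Lengthening a short chain by one carbon is a small change, and nothing in the data points to a shift beyond the scatter in this assay. For compound 3 the expected step is a 1.3-fold higher number from compound 2 to compound 3 (0.10 log units; within the scatter). Compound 3 is estimated at 1 nM, with a range from 0.4 nM to 2.5 nM.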

Compound 3, half-maximal inhibitory concentration: 2 nM
The estimate for compound 3 lay 2.0-fold (0.30 log units) below the measured number; the measured number falls inside the stated range.
By their numbers in this assay, from the lowest: compound 2; then compound 3; then compound 1.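

In this assay, within the data shown here, the step from ethyl to propyl on the amine nitrogen is the first measured change to that chain alone, and a 2.5-fold higher number from compound 2 to compound 3 (0.40 log units; beyond the scatter) shows that one added methyl at this position can shift the number, modestly but measurably. The propyl compound still sits well clear of the methyl and tetrazole compound, with an 8.0-fold lower number from compound 1 to compound 3 (0.90 log units; beyond the scatter) for the swap of the whole amine group, so the longer chain does not cancel the gain seen with the ethyl compound. No evidence is available to explain why the extra carbon raises the number.

On these data alone, whether the number keeps rising with a longer chain such as butyl, or behaves differently with a branched chain such as isopropyl, remains open. A plain methyl on the amine nitrogen alongside the same 5-hydroxy-1H-1,2,4-triazol-3-yl ring would be needed to separate the effect of the chain from that of the ring.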